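The source may report more compounds than this note shows. Statements on the series, on what has been measured and on what is new or still open speak of the compounds shown alone.

Measured compounds in an assay on isolated protein for inhibition of sodium-dependent dopamine transporter (Rattus norvegicus), read by radioligand binding; a lower number here means a stronger inhibitor, a higher number a weaker inhibitor:
compound 1 `COC(=O)C[S+]([O-])CC1CN(C)CCC1c1ccc(Cl)cc1`: 231 nM
compound 2 `CN1CCC(c2ccc(Cl)cc2)C(C[S+]([O-])CCO)C1`: 12 nM
compound 3 `COCC[S+]([O-])CC1CN(C)CCC1c1ccc(Cl)cc1`: 15 nM

Compound 3 stands second of the three numbers. Its nearest neighbour is compound 2, and the step of a 1.3-fold higher number from compound 2 to compound 3 (0.10 log units; within the scatter) is within the scatter, so the two cannot be ordered. The step of a 15-fold lower number from compound 1 to compound 3 (1.19 log units; beyond the scatter) and the step of a 19-fold lower number from compound 1 to compound 2 (1.28 log units; beyond the scatter) are both large, and both remove the methoxycarbonyl from the chain carbon bound to sulfur.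

Compound 4 `CC(=O)OCCSCC1CN(C)CCC1c1ccc(Cl)cc1` is not yet measured. Relative to compound 3 the change is a group of 7 heavy atoms (4 carbon, 2 oxygen, 1 sulfur; no ring) in place of a group of 6 heavy atoms (3 carbon, 2 oxygen, 1 sulfur; no ring), on a saturated chain carbon bound to a saturated ring carbon. Two things move at once: the oxygen on sulfur is gone, and the methoxy on the two-carbon chain becomes an acetoxy. Within the data shown here, no measured pair shows a sulfide beside a sulfoxide, so that part of the change is unsupported. The change at the chain oxygen resembles the step from compound 2 to compound 3, which was within the scatter, though an acetyl is not a methyl, and compound 1 warns that an ester can cost a great deal when placed on the carbon bound to sulfur. On balance a modest loss is expected for compound 4, as a 2.0-fold higher number from compound 3 to compound 4 (0.30 log units; within the scatter), giving an estimate of 30 nM with a range of 8 nM to 120 nM.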

Compound 4, inhibition constant: 35 nM
The estimate for compound 4 lay 1.2-fold (0.07 log units) below the measured number; measured number inside the range.
By their numbers in this assay, from the lowest: compounds 2 and 3 (each within the scatter of the next); then compound 4; then compound 1.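

In this assay the (2-acetoxyethyl)sulfanyl group on a saturated chain carbon bound to a saturated ring carbon costs only modestly against the earlier side chains, with a 2.3-fold higher number from compound 3 to compound 4 (0.37 log units; beyond the scatter) and a 2.9-fold higher number from compound 2 to compound 4 (0.46 log units; beyond the scatter) as the two readings, both small but beyond the scatter. An ester in this side chain is therefore not in itself as costly as the methoxycarbonyl of compound 1 suggested, since a 6.6-fold lower number from compound 1 to compound 4 (0.82 log units; beyond the scatter) still leaves compound 4 clearly the stronger inhibitor of that pair, although that step also changes the oxygen on sulfur and the place of the ester. No measurement shown here bears on the reason for any of these steps.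

Each step to compound 4 removes the oxygen on sulfur and alters the chain end together, so the share of each change stays unresolved until a sulfide carrying the methoxy or hydroxyl chain end can be set against compound 3 or compound 2. From the compounds shown here alone, how an amine or a carboxylic acid at the chain end, or a longer chain, would read in this assay also stays open.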